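Adding a Phenyl to Compound 2

The source may report more compounds than this note shows. Statements on the series, on what has been measured and on what is new or still open speak of the compounds shown alone.

Compound 1 `CCN1C(N2CCCCC2)=Nc2ccccc2C1CC(=O)NCc1ccc(NS(=O)(=O)c2ccc(F)cc2)cc1` and compound 2 `CC(C)(C)OC(=O)NCCCCCNC1=Nc2ccccc2C(CC(=O)NCc2ccccc2)N1c1ccccc1` share a core but differ at several places. In a functional assay on HT-29 cells (Homo sapiens) for inhibition, read by sulforhodamine B assay, with a stated time of 72 h (on this read-out higher numbers stand for weaker inhibition of growth and lower numbers for stronger inhibition of growth), compound 1 gives 13900 nM, while compound 2 gives 3180 nM, the lower of the two numbers, a gap that lies beyond the usual scatter. Compound 3 `CC(C)(C)OC(=O)NCCCCCNC1=Nc2ccccc2C(CC(=O)NCc2ccccc2)N1c1ccc(-c2ccccc2)cc1` is compound 2 with phenyl in place of hydrogen on an aromatic carbon. For the measured compounds named here, no measured pair shows this change, so its step is unknown; a modest shift, not clearly beyond the scatter, is expected. Compound 3 is therefore estimated at 2500 nM in this assay, within 700 nM to 9000 nM. The expected step is a 1.3-fold lower number from compound 2 to compound 3 (0.10 log units; within the scatter).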

Compound 3, concentration for 50% growth inhibition: 1670 nM
Compound 3: the middle estimate sits 1.5-fold (0.18 log units) above what was measured, within the range that was stated.
By their numbers in this assay, from the lowest: compounds 3 and 2 (each within the scatter of the next); then compound 1.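

In this assay, placing phenyl on this aromatic carbon, para to a large group, gives a 1.9-fold lower number from compound 2 to compound 3 (0.28 log units; within the scatter). The two compounds therefore cannot be told apart, so this position can carry a whole extra six-membered aromatic ring with no loss of growth inhibition beyond the scatter. No available evidence explains this result. Still open, going by these compounds, is whether an amine or a carboxylic acid at this same carbon would read like phenyl, and whether a second ring attached through a longer chain would do the same.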